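Moving One Fluorine: Compound 2 to Compound 4

A few compounds are considered here, and "the series" means these few. Any claim that something is new, unique, unknown or untested is made for them only; others in the source may bear on it.

In a functional assay on Ehrlich cells (Mus musculus) for cytotoxicity, read by LDH release, with a stated time of 48 h (on this read-out lower numbers stand for stronger inhibition and higher numbers for weaker inhibition), compound 2 `Cc1cc(C(=O)c2ccc(F)cc2)ccc1OCC(=O)Nc1nc(-c2ccccc2)cs1` gives 38600 nM and stands level with compound 1 `Cc1ccc(C(=O)c2ccc(OCC(=O)Nc3nc(-c4ccccc4)cs3)c(C)c2)cc1` at 30500 nM on this scale. Compound 3 `COc1ccc(-c2csc(NC(=O)COc3ccc(C(=O)c4ccc(F)cc4)cc3C)n2)cc1` gives a clearly lower number (5800 nM). Compound 4 `Cc1cc(C(=O)c2ccccc2F)ccc1OCC(=O)Nc1nc(-c2ccccc2)cs1` has the same atoms as compound 2, joined differently, with 2-fluorophenyl in place of 4-fluorophenyl on a carbonyl carbon. Among the compounds with values here, no measured step makes this exact change. The closest evidence is fluoro in place of methyl on an aromatic carbon of the group that changes here (a 1.3-fold higher number from compound 1 to compound 2 (0.10 log units; within the scatter)). That swap of one group for another left the number essentially unmoved. The larger step (a 6.7-fold lower number from compound 2 to compound 3 (0.82 log units; beyond the scatter)) came from methoxy in place of hydrogen on an aromatic carbon, which is a different change, so it is not carried over. No step beyond the scatter is therefore expected in this assay, and the estimated step is small (a 1.2-fold lower number from compound 2 to compound 4 (0.07 log units; within the scatter)). Compound 4 is expected near 33000 nM with an estimated range of values (15000 nM to 70000 nM).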

Compound 4, half-maximal inhibitory concentration: 16900 nM
Estimate against measurement, compound 4: 2.0-fold (0.29 log units) above; the range from low to high includes it.
By their numbers in this assay, from the lowest: compound 3; then compounds 4, 1 and 2 (each within the scatter of the next, the first and the last beyond it).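

In this assay the swap of 4-fluorophenyl for 2-fluorophenyl on the carbonyl carbon gives a 2.3-fold lower number from compound 2 to compound 4 (0.36 log units; beyond the scatter) even though no atom is gained or lost, so where the fluorine sits on this ring matters, which the earlier change from 4-methylphenyl to 4-fluorophenyl could not show. Measured against the 4-methylphenyl group, the same 2-fluorophenyl group gives a 1.8-fold lower number from compound 1 to compound 4 (0.26 log units; within the scatter) and so does not separate compound 4 from compound 1, which means the effect of the move is seen only against 4-fluorophenyl. Nothing measured here explains this effect of the fluorine's place.

On these data alone, it remains open whether the same move would matter with the methoxy group of compound 3 present. As far as these compounds go, it is also open how a chlorine or an amine in place of the fluorine on this ring would behave.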